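This account rests on a few compounds, and the source may have more. Where it says the series, first, only, none or still open, it means among the compounds named here.

Going by the values given here, in an in vitro functional assay on HEK293-A cells for positive allosteric modulation of metabotropic glutamate receptor 5 (Homo sapiens), read by fluorescence and calcium flux, with a stated time of 140 s (a lower number here means that less compound is needed, a higher number that more compound is needed for the effect), compound 1 `O=C(C1CCC1)N1CCCC1c1nc(-c2cccc(F)c2)no1` gives 1500 nM; 1500 nM (2 entries), while compound 2 `O=C(C1CCC1)N1CCC[C@H]1c1nc(-c2cccc(F)c2)no1` gives 7000 nM, the only number recorded for it beside one further entry without a number. The pair is set apart by the fact that one of compounds 1 and 2 is drawn with a defined configuration and the other without, at the place where they differ. Compound 3 `O=C(C1CCC1)N1CCC[C@@H]1c1nc(-c2cccc(F)c2)no1` differs from compound 2 in that (the two compounds have the same atoms and bonds and differ only in configuration as drawn: 1 of 1 stereo elements differ; a stereocentre at a saturated ring carbon is drawn S in compound 2 and R in compound 3). Among the compounds with values here, no step between measured compounds is available. Compound 1 at 1500 nM; 1500 nM (2 entries) stands well under compound 2 at 7000 nM, so the expected step is a 7.8-fold lower number from compound 2 to compound 3 (0.89 log units; beyond the scatter), toward less compound being needed. Compound 3 is therefore estimated at 900 nM, with a range from 300 nM to 2500 nM.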

Compound 3, half-maximal effective concentration: 530 nM
Beside the measured number, compound 3's estimate is 1.7-fold (0.23 log units) above it; the measured number falls inside the stated range.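

Inverting the stereocentre at the saturated ring carbon from S to R gives a 13-fold lower number from compound 2 to compound 3 (1.12 log units; beyond the scatter) in this assay. Going by these compounds alone, this is the first reading of this position with each configuration defined, and the large step can be tied to that stereocentre alone because of how the structures relate: the fact that compounds 2 and 3 differ only in the configuration as drawn Compound 1, drawn without a defined configuration, gives 1500 nM; 1500 nM (2 entries), which lies between the values of the two defined forms.

The compounds shown leave open whether the R configuration keeps this advantage when the fluorine gives way to a nitrile or a methoxy group, or when the carbonyl carries a longer chain.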